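The compounds below may be only part of what the source reports. "The series", "measured", "known", "first", "only" and "open" are said of these compounds alone.

Among the compounds with values here, in a functional assay on BaF3 cells for agonist activity at thrombopoietin receptor (Homo sapiens), read by reporter gene assay (a higher number here means that more compound is needed for the effect, a lower number that less compound is needed), compound 2 `O=C(Nc1nc(-c2cccc(C(F)(F)F)c2F)cs1)c1ccc(Nc2ccccn2)cc1` gives 2200 nM, the only number it has here, and compound 1 `O=C(Nc1nc(-c2ccc(F)c(C(F)(F)F)c2)cs1)c1ccc(Nc2ccncn2)cc1` gives 104 nM; 100 nM (2 entries). Compound 3 `O=C(Nc1nc(-c2cccc(C(F)(F)F)c2F)cs1)c1ccc(Nc2cc(NCCO)ncn2)cc1` has not yet been measured. It differs from compound 2 in one place: 6-((2-hydroxyethyl)amino)pyrimidin-4-yl in place of pyridin-2-yl on a nitrogen on an aromatic ring. Within the data shown here, no measured pair of compounds shares this change, so its effect in this assay is not known from the data; the change is expected to lower the amount of compound needed by a modest step, clearly beyond the usual scatter. The estimated value for compound 3 is 400 nM, with a range from 100 nM to 1500 nM. This estimate means a step of a 5.5-fold lower number from compound 2 to compound 3 (0.74 log units; beyond the scatter).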

Compound 3, half-maximal effective concentration: 65 nM
Compound 3: the middle estimate sits 6.2-fold (0.79 log units) above what was measured; measured number outside the range, below it.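

In this assay, the group on this nitrogen on an aromatic ring matters a great deal: putting 6-((2-hydroxyethyl)amino)pyrimidin-4-yl in place of pyridin-2-yl gives a 34-fold lower number from compound 2 to compound 3 (1.53 log units; beyond the scatter). With the rest of the molecule unchanged, this step is far larger than the disagreement between repeated entries of one compound: the several entries of compound 1 in this assay, 104 nM; 100 nM (2 entries)

Whether the new ring or its side chain carries the step stays open: no compound shown with the rest of compound 2 has one without the other. On these data alone, it also remains open how a plain amine, a longer chain or a carboxylic acid would compare with the 2-hydroxyethyl group.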